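The source may hold more compounds than are shown below. What is called first, only, known or untested is meant among the compounds shown, and "the series" means these compounds.

Measured compounds:
- compound 1 `CCC(CC)n1c(-c2ccc(OCc3c(-c4c(Cl)cccc4Cl)noc3C(C)C)cc2Cl)nc2ccc(C(=O)O)cc21`: 21.6 nM
- compound 2 `CC(C)c1onc(-c2c(Cl)cccc2Cl)c1COc1ccc(-c2nc3ccc(C(=O)O)cc3n2C2CCC2)cc1`: "not determined" (no result reported)
- compound 3 `CC(C)c1onc(-c2c(Cl)cccc2Cl)c1COc1ccc(-c2nc3ccc(C(=O)O)cc3n2CC2CCCCC2)c(Cl)c1`: 66.1 nM

Compound 2 stands without a number in an assay on isolated protein for agonist activity at Bile acid receptor (Homo sapiens), read by TR-FRET; on this read-out higher numbers stand for an effect only at larger amounts of compound and lower numbers for an effect already at smaller amounts; its place in the series cannot be set from the measurements shown. Compound 4 `CCCC(CCC)n1c(-c2ccc(OCc3c(-c4c(Cl)cccc4Cl)noc3C(C)C)cc2)nc2ccc(C(=O)O)cc21` arises from compound 2 by the change (1-propylbutyl in place of cyclobutyl on an aromatic nitrogen).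

For the measured compounds named here, the only measured step at the same position is a 3.1-fold higher number from compound 1 to compound 3 (0.49 log units; beyond the scatter), a change from a branched chain to a ring-bearing group on the aromatic nitrogen. The step from compound 2 to compound 4 runs the other way, from a small ring to a branched chain, and there is no value for compound 2 to anchor it. Compound 4 carries a branched chain of the same kind as compound 1 but differs from compound 1 in more than one place, so its value for compound 1 gives only a rough orientation. Compound 4 is therefore expected to lie near the better end of the measured range, estimated at 40 nM, with a range from 12 nM to 130 nM.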

Compound 4, half-maximal effective concentration: 30.3 nM
Compound 4: middle estimate off by 1.3-fold (0.12 log units), on the high side; the range from low to high includes it.
By their numbers in this assay, from the lowest: compounds 1 and 4 (each within the scatter of the next); then compound 3.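

In this assay, for the compounds shown here, compound 4 gives 30.3 nM but compound 2 has no number, so no step from compound 2 to compound 4 can be read. No evidence bears on this result. Still open, as far as these compounds go, is how 1-propylbutyl in place of cyclobutyl on the aromatic nitrogen shifts the number in this assay for this pair.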